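The source may hold more compounds than are shown below. What is called first, only, known or untested is meant among the compounds shown, and "the series" means these compounds.

Measured so far in a functional assay on the whole organism for antagonist activity, with Mus musculus as the target; on this read-out higher numbers stand for an effect only at larger amounts of compound and lower numbers for an effect already at smaller amounts:

Compound 1 `CCOC(=O)N(C)CC#CCN1CCCC1`: in this assay compound 1 gives > 100 mg/kg, which is a limit of the assay and not a number.
Compound 2 `CCOC(=O)N(C)CC#CCn1ccnc1`: in this assay compound 2 gives 97 mg/kg.
Compound 3 `CN(C)C(=O)N(C)CC#CCN1CCCC1`: in this assay compound 3 gives > 10 mg/kg, again a limit of the assay and not a number.

Compound 2 differs from compound 1 by 1H-imidazol-1-yl in place of pyrrolidin-1-yl on a saturated chain carbon bound to a triple-bonded carbon. Within the data shown here, that step, an at least 1.0-fold lower number from compound 1 to compound 2 (0.01 log units; that floor lies within the scatter), rests on the limit of > 100 mg/kg in this assay, at which 1 of the 3 values shown sits, and so says only that the two values are not far apart. Compound 3 differs from compound 1 by dimethylamino in place of ethoxy on a carbonyl carbon; here a step that the two limits leave unreadable from compound 1 to compound 3, since both the limit of > 10 mg/kg in this assay, at which 1 of the 3 values shown sits, and the limit of > 100 mg/kg in this assay, at which 1 of the 3 values shown sits, are involved.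

Compound 4 `CN(C)C(=O)N(C)CC#CCn1ccnc1` is not yet measured. It differs from compound 3 by 1H-imidazol-1-yl in place of pyrrolidin-1-yl on a saturated chain carbon bound to a triple-bonded carbon, the same kind of change as that from compound 1 to compound 2; the place line reads the same in both cases. Given that the earlier step, an at least 1.0-fold lower number from compound 1 to compound 2 (0.01 log units; that floor lies within the scatter), did not move the read-out beyond the scatter, compound 4 is expected to stay close to compound 3, and the step is estimated as a step that the limit leaves unreadable from compound 3 to compound 4. For compound 4 the value in this assay is estimated at 60 mg/kg, with a range from 15 mg/kg to 300 mg/kg, and a real chance that only a limit is reported.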

Compound 4, dose for half-maximal effect: > 100 mg/kg
Compound 4 gave a limit, no number (the forecaster's own chance of this, stated with the estimate: 50%); middle value at least 1.6-fold (0.22 log units) from the limit.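

In this assay compound 4 gives > 100 mg/kg, a limit of the assay and not a number, and the step to it from compound 3 cannot be read, so 1H-imidazol-1-yl in place of pyrrolidin-1-yl has no readable size on this core: the limit of > 100 mg/kg in this assay, at which 2 of the 4 values shown sit. With 1H-imidazol-1-yl on the chain, dimethylamino in place of ethoxy on a carbonyl carbon gives an at least 1.0-fold higher number from compound 2 to compound 4 (0.01 log units; that floor lies within the scatter), and this floor shows no real difference while leaving a larger one possible. The result therefore neither confirms nor rules out that the change of ring carries over from the core of compound 1 to the core of compound 3.

Still open, as far as these compounds go, is where compound 1, compound 3 and compound 4 lie as numbers rather than limits. Also open, from the compounds shown here alone, is how either core responds to piperidin-1-yl or diethylamino on a saturated chain carbon bound to a triple-bonded carbon.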